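The source may report more compounds than this note shows. Statements on the series, on what has been measured and on what is new or still open speak of the compounds shown alone.

Of the compounds shown here, two have numbers so far in an ADME assay on C8166 cells (Homo sapiens) for cytotoxicity, read by MTT assay; on this read-out lower numbers stand for higher toxicity in this test and higher numbers for lower toxicity in this test. Compound 1 (`CC(C)[C@@H](CO)n1cc(C(=O)O)c(=O)c2c(O)c(Cc3cccc(Cl)c3F)ccc21`) gives 125000 nM, and compound 2 (`O=C(O)c1cn(Cc2ccccc2F)c2ccc(Cc3ccccc3F)c(O)c2c1=O`) gives 67100 nM. Among the measured compounds shown here, these two values lie within the usual scatter of each other, so compound 2 cannot be separated from compound 1, the only other compound measured. The two also differ in more than one place, so neither value shows the effect of a single change.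

Compound 3 (`O=C(O)c1cn(Cc2ccccc2F)c2ccc(Cc3cccc(Cl)c3F)c(O)c2c1=O`) departs from compound 2 at one point: chloro in place of hydrogen on an aromatic carbon. This is chloro in place of hydrogen on an aromatic carbon, ortho to a fluoro group, which turns 2-fluorobenzyl into 3-chloro-2-fluorobenzyl. For the measured compounds named here, no measured pair shows what this change does in this assay, so no step beyond the scatter is expected, in either direction. Going by the values given here, the only direct guide is compound 2 at 67100 nM. The estimated step is small, a 1.1-fold lower number from compound 2 to compound 3 (0.05 log units; within the scatter), and stays within the scatter. Compound 3 is expected at about 60000 nM, with an estimated range from 25000 nM to 130000 nM.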

Compound 3, half-maximal cytotoxic concentration: 44900 nM
Estimate against measurement, compound 3: 1.3-fold (0.13 log units) above, and the stated range covers the measured number.
By their numbers in this assay, from the lowest: compounds 3, 2 and 1 (each within the scatter of the next, the first and the last beyond it).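

In this assay the chloro, on an aromatic carbon ortho to a fluoro group, leaves the number within the scatter (a 1.5-fold lower number from compound 2 to compound 3 (0.17 log units; within the scatter)), so 3-chloro-2-fluorobenzyl cannot be told apart from 2-fluorobenzyl here. Among the compounds shown here, compound 3 also gives the first comparison at the aromatic nitrogen that differs in one place: 2-fluorobenzyl in place of 1-(hydroxymethyl)-2-methylpropyl brings a modest step beyond the scatter (a 2.8-fold lower number from compound 1 to compound 3 (0.44 log units; beyond the scatter)), and of the two single changes now readable, only this one separates its compounds. Nothing available gives a reason for either result.

The compounds shown leave open how this read-out responds to other groups at the chloro position, such as methoxy or an amine, and whether a chloro there would leave the number within the scatter with another substituent on the aromatic nitrogen. They also leave open whether the step at that nitrogen belongs to the 2-fluorobenzyl ring itself, since a plain benzyl or a simple longer alkyl chain does not appear among them.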